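The source may report more compounds than this note shows. Statements on the series, on what has been measured and on what is new or still open speak of the compounds shown alone.

Compound 2, whose structure is `CCC1(OC(=O)N2CCC(Oc3ncnc(Oc4ccc(S(C)(=O)=O)nc4C)c3F)CC2)CC1`, is the starting point here. In a functional assay on isolated protein for inhibition of Glucose-dependent insulinotropic receptor (Homo sapiens), read by HTRF and cAMP accumulation (a lower number here means that less compound is needed, a higher number that more compound is needed for the effect), compound 2 gives 22 nM. Among the three compounds measured it holds the second highest number: compound 1 `Cc1nc(S(C)(=O)=O)ccc1Oc1ncnc(OC2CCN(C(=O)OC(C)(C)C(F)(F)F)CC2)c1F` gives 6.53 nM, and compound 3 `Cc1nc(S(C)(=O)=O)ccc1Oc1ncnc(OC2CCN(C(=O)C3(C)CC3)CC2)c1F` gives 761 nM. The step of a 3.4-fold higher number from compound 1 to compound 2 (0.53 log units; beyond the scatter) is modest, whereas the step of a 35-fold higher number from compound 2 to compound 3 (1.54 log units; beyond the scatter) is large, as is the step of a 120-fold higher number from compound 1 to compound 3 (2.07 log units; beyond the scatter).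

Compound 4 `Cc1nc(S(C)(=O)=O)ccc1Oc1ncnc(OC2CCN(C(=O)c3noc(C(C)C)n3)CC2)c1F` is not yet measured. It changes the group on the carbonyl carbon: a group of 8 heavy atoms (5 carbon, 2 nitrogen, 1 oxygen; one five-membered aromatic ring with 3 hetero atoms) in place of a group of 6 heavy atoms (5 carbon, 1 oxygen; one three-membered non-aromatic ring of carbon only), on a carbonyl carbon. The two steps that bear on this both remove the oxygen-linked group from the carbonyl carbon, and both cost a great deal of potency, as the step from compound 2 to compound 3 and the step from compound 1 to compound 3 show. Compound 4 likewise loses that oxygen-linked group, though the aromatic ring that enters is larger and carries more acceptors than the small ring in compound 3, so the outcome need not be as severe. A clear move toward a higher number is therefore expected for compound 4, with the step estimated as a 6.8-fold higher number from compound 2 to compound 4 (0.83 log units; beyond the scatter). In this assay compound 4 is estimated at 150 nM, within a range from 30 nM to 800 nM.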

Compound 4, half-maximal effective concentration: 21.2 nM
The estimate for compound 4 lay 7.1-fold (0.85 log units) above the measured number; measured number outside the range, below it.
By their numbers in this assay, from the lowest: compound 1; then compounds 4 and 2 (each within the scatter of the next); then compound 3.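

The 5-isopropyl-1,2,4-oxadiazol-3-yl group has no oxygen link to the carbonyl carbon, yet a 1.0-fold lower number from compound 2 to compound 4 (0.02 log units; within the scatter) puts this compound level with the oxygen-linked 1-ethylcyclopropyl compound, so among these compounds the high number of compound 3 cannot be put down simply to the loss of that oxygen link. What sits on the carbonyl carbon matters greatly even without the oxygen, since a 36-fold lower number from compound 3 to compound 4 (1.56 log units; beyond the scatter) separates two compounds that both lack it, while a 3.2-fold higher number from compound 1 to compound 4 (0.51 log units; beyond the scatter) leaves compound 1, with its 1-methyl-1-(trifluoromethyl)ethoxy group, still the lowest of the four. Nothing available explains why the oxadiazole behaves so differently from the 1-methylcyclopropyl group. The compounds shown cannot separate the part played by the five-membered aromatic ring from that of its isopropyl group, so a 5-methyl-1,2,4-oxadiazol-3-yl or a plain phenyl ring on the same carbonyl carbon would be an informative comparison. Whether a ring of this kind could also reach the number of compound 1 remains an open question.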